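Swapping one small heteroaromatic ring on a sulfur

The source may report more compounds than this note shows. Statements on the series, on what has been measured and on what is new or still open speak of the compounds shown alone.

Measured compounds:
compound 1 `Cc1ccc(-c2cs/c(=N/NC(=O)CSc3nnnn3-c3ccccc3)n2-c2ccccc2)cc1` gives 22.2%
compound 2 `COc1ccc(-c2cs/c(=N/NC(=O)CSc3nnc(C)s3)n2-c2ccccc2)cc1` gives 22.2%
compound 3 `Cc1ccc(-c2cs/c(=N/NC(=O)CSc3nncn3C)n2-c2ccccc2)cc1` gives 27.8%

All three were tested in a functional assay on C6 cells (Rattus norvegicus) for cytotoxicity, read by MTT assay, with a stated time of 24 h, tested at 200 ug/mL; on this read-out lower numbers stand for a stronger effect and higher numbers for a weaker effect at the one concentration tested. For the measured compounds named here, compound 3 does not stand apart from the others: the only single-point step among them, a number 5.6 percentage points higher from compound 1 to compound 3 (within the scatter), is within the scatter, and the gap from compound 3 to compound 2 is of the same size. On these numbers the three compounds cannot be told apart.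

Compound 4 `Cc1ccc(-c2cs/c(=N/NC(=O)CSc3nnc(C)s3)n2-c2ccccc2)cc1` has not yet been measured. It differs from compound 3 in one place: 5-methyl-1,3,4-thiadiazol-2-yl in place of 4-methyl-4H-1,2,4-triazol-3-yl on a sulfur. Going by the values given here, the one measured step that bears on this position, a number 5.6 percentage points higher from compound 1 to compound 3 (within the scatter), exchanged one small heteroaromatic ring on the same sulfur for another and produced no movement beyond the scatter. Compound 2 already carries the 5-methyl-1,3,4-thiadiazol-2-yl group on its sulfur and gives 22.2%, a number level with compound 1 and compound 3.

The expectation for this assay is therefore no step beyond the scatter from compound 3, estimated as a number 3.8 percentage points lower from compound 3 to compound 4 (within the scatter). Compound 4 is estimated to give 24%, within a range from 13% to 35%.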

Compound 4, a percentage reported as activity, at one concentration (the size of the read-out at that concentration, not a potency): 13.3%
For compound 4 the middle estimate is 10.7 percentage points above the measured one, and the stated range covers the measured number.
By their numbers in this assay, from the lowest: compounds 4, 1, 2 and 3 (each within the scatter of the next, the first and the last beyond it).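

In this assay, for the compounds shown here, the ring on this sulfur can matter after all: a number 14.5 percentage points lower from compound 3 to compound 4 (beyond the scatter) is the first step at this position to pass the scatter, yet the two groups have the same heavy-atom and hydrogen-bond counts, and the entering group has a sulfur in its atom count where the leaving group has a nitrogen. The change is not a general gain, since a number 8.9 percentage points lower from compound 1 to compound 4 (within the scatter) stays within the scatter, so 5-methyl-1,3,4-thiadiazol-2-yl is set apart from 4-methyl-4H-1,2,4-triazol-3-yl but not from 1-phenyl-1H-tetrazol-5-yl, and a number 8.9 percentage points lower from compound 2 to compound 4 (within the scatter), the exchange of methoxy for methyl on an aromatic carbon, also stays within it. Nothing available explains why this ring exchange moves the number.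

The compounds shown leave open whether the step from the triazole to the thiadiazole holds with methoxy in place of the methyl on the aromatic carbon. They also leave open what happens when the methyl on the thiadiazole ring gives way to an amine, a carboxylic acid or a longer chain.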